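Removing a Methoxy Group from Two Inactive Compounds

The source may hold more compounds than are shown below. What is called first, only, known or untested is meant among the compounds shown, and "the series" means these compounds.

Compound 1, `COc1ccc2nc(C3CCC3)nc(N3CCN(c4ccccc4OC)CC3)c2c1`, in an in vitro assay on U2OS cells for agonist activity at neurotensin receptor type 2 (Homo sapiens), read by reporter gene assay and beta-arrestin recruitment; a lower number here means that less compound is needed, a higher number that more compound is needed for the effect: > 80000 nM, a limit of the assay rather than a number.
Compound 2, `COc1ccc2c(N3CCN(c4ccccc4OC)CC3)nc(C3CCC3)nc2c1`, in this assay: > 80000 nM, likewise a limit and not a number.

Compound 2 therefore stands at the ceiling of what this assay can report. Within the data shown here, the whole record consists of the limit of > 80000 nM in this assay, at which 2 of the 2 values shown sit, so no measured compound offers a number to compare, and no step between measured compounds can be computed.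

Compound 3, `COc1ccccc1N1CCN(c2nc(C3CCC3)nc3ccccc23)CC1`, remains to be measured. Against compound 2 it carries hydrogen in place of methoxy on an aromatic carbon, that is, hydrogen in place of methoxy on an aromatic carbon. The two measured compounds give nothing that would indicate whether losing the methoxy moves a compound off the limit in this assay. The step is expected to be none beyond the scatter, a number no higher from compound 2 to compound 3 (the limit leaves the size open). Compound 3 is thus expected to read about 80000 nM in this assay, within a range from 20000 nM to 300000 nM, most probably returned again as a limit.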

Compound 3, half-maximal effective concentration: > 80000 nM
Compound 3: no number, only a limit (the forecaster's own chance of this, stated with the estimate: 80%); the middle value lies on the limit itself.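

In this assay compound 3 gives > 80000 nM as a limit of the assay and not a number. Among these compounds, no step from compound 1 or compound 2 to compound 3 can be read: the limit of > 80000 nM in this assay, at which 3 of the 3 values shown sit. The compounds shown leave open whether hydrogen in place of methoxy on an aromatic carbon changes anything in this assay at all.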